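From Methoxy to Trifluoromethyl: One Change on a Shared Core

This account rests on a few compounds, and the source may have more. Where it says the series, first, only, none or still open, it means among the compounds named here.

Measured so far:
compound 1, `Fc1ccccc1-c1c[nH]c(=S)s1`: 29%
compound 2, `Fc1ccccc1-c1csc(=S)[nH]1`: 77%
compound 3, `COc1ccc(-c2csc(=S)[nH]2)cc1`: 68%

All three were tested in an assay on isolated protein for inhibition of Indoleamine 2,3-dioxygenase 1 (Homo sapiens), read by colorimetric assay, with stated times of 10 min and 30 min, tested at 100 uM; a lower number here means less inhibition, a higher number more inhibition at the concentration tested (going by the name of the read-out). On these numbers compound 3 stands second highest of the three. Its nearest neighbour is compound 2, whose value lies within the usual scatter of repeated measurements, so no order between the two can be claimed. Its furthest neighbour is compound 1, whose value lies well beyond the scatter on the low side.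

Compound 4, `FC(F)(F)c1ccc(-c2csc(=S)[nH]2)cc1`, has not yet been measured. It differs from compound 3 in a single place: trifluoromethyl in place of methoxy on an aromatic carbon. For the measured compounds named here, no two measured compounds differ from each other in only one place, so there is no measured step of this kind to lean on. In this assay the expectation is a step of modest size, not clearly beyond the scatter; the estimated step from compound 3 to compound 4 is a number 8 percentage points lower from compound 3 to compound 4 (within the scatter). Compound 4 is therefore expected to give about 60%, with a likely range from 35% to 85%.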

Compound 4, a percentage reported as inhibition, at one concentration (the size of the read-out at that concentration, not a potency): 37%
The estimate for compound 4 lay 23 percentage points above the measured number, and the stated range covers the measured number.
By their numbers in this assay, from the lowest: compounds 1 and 4 (each within the scatter of the next); then compounds 3 and 2 (each within the scatter of the next).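

In this assay, trifluoromethyl in place of methoxy gives a number 31 percentage points lower from compound 3 to compound 4 (beyond the scatter), so this is not an interchangeable swap. It is the first step shown in which only one place differs, and it shows that the group on this aromatic carbon can, with the rest of the molecule unchanged, shift the inhibition by more than the usual scatter. Nothing available here accounts for the size of this step, so its cause remains unknown.

With only two groups compared at this position, the compounds shown leave open whether the step reflects losing methoxy, gaining trifluoromethyl, or both. A plain hydrogen, an amine or a carboxylic acid on the same aromatic carbon would help separate these possibilities and show whether the trend extends beyond this single pair.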